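A few compounds are considered here, and "the series" means these few. Any claim that something is new, unique, unknown or untested is made for them only; others in the source may bear on it.

Compound 1 `Nc1ccccc1NC(=O)CCCCCCc1nc(-c2ccccc2)no1` — in an assay on isolated protein for inhibition of histone deacetylase 8 (Homo sapiens), read by fluorescence, with a stated time of 10 min (a lower number here means a stronger inhibitor, a higher number a weaker inhibitor), compound 1 gives > 10000 nM, a limit of the assay.
Compound 2 `Nc1ccccc1NC(=O)CCCCCCc1nc(-c2ccccc2Cl)no1` — in this assay compound 2 gives > 10000 nM, a limit.
Compound 3 `Nc1ccccc1NC(=O)CCCCCCc1nc(-c2cccc([N+](=O)[O-])c2)no1` — in this assay compound 3 gives > 10000 nM, a limit.

Compound 3 thus stands nowhere above the others: all three share (the limit of > 10000 nM in this assay, at which 3 of the 3 values shown sit), so no order among them can be read. Compound 4 `O=C(CCCCCCc1nc(-c2cccc([N+](=O)[O-])c2)no1)C(F)(F)F` differs from compound 3 by trifluoromethyl in place of (2-aminophenyl)amino on a carbonyl carbon. Among the compounds with values here, no measured step touches that carbonyl. The steps on record, a step that the two limits leave unreadable from compound 1 to compound 2, a step that the two limits leave unreadable from compound 1 to compound 3 and a step that the two limits leave unreadable from compound 2 to compound 3, all alter the aromatic substituent, and each is unreadable, so they give no size or direction to carry over. Going by these compounds, the change to compound 4 is larger than any of them and remains open. The estimate for compound 4 in this assay is 3000 nM, between 200 nM and 30000 nM, an expected step of an at least 3.3-fold lower number from compound 3 to compound 4 (0.52 log units; beyond the scatter).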

Compound 4, half-maximal inhibitory concentration: 830 nM
Compound 4: the middle estimate sits 3.6-fold (0.56 log units) above what was measured, within the range that was stated.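

In this assay, within the data shown here, trifluoromethyl in place of (2-aminophenyl)amino on the carbonyl carbon gives the first step that can be read: an at least 12-fold lower number from compound 3 to compound 4 (1.08 log units; beyond the scatter). Compound 3 holds only a limit, so this step gives a bound and not an exact size. The steps among the aromatic substituents cannot be read, which makes the carbonyl the first place shown where a change leaves the limit: the limit of > 10000 nM in this assay, at which 3 of the 4 values shown sit.

A hydroxyamino group or a methyl group on this carbonyl would help show which part of the change matters. Whether the aromatic substituent matters with trifluoromethyl in place also stays open, with only the 3-nitrophenyl form shown.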